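This account rests on a few compounds, and the source may have more. Where it says the series, first, only, none or still open, it means among the compounds named here.

Measured compounds in a functional assay on HT-29 cells (Homo sapiens) for cytotoxicity, read by MTT assay, with a stated time of 72 h; on this read-out higher numbers stand for weaker inhibition of growth and lower numbers for stronger inhibition of growth:
compound 1 `CC(C)COC(=O)Nc1ccc([Se]C#N)cc1`, 8100 nM
compound 2 `C=CCOC(=O)Nc1ccc([Se]C#N)cc1`, 24500 nM
compound 3 `N#C[Se]c1ccc(NC(=O)OCc2ccc([N+](=O)[O-])cc2)cc1`, 22400 nM

Compound 3 stands second highest of the three numbers. Its value and that of compound 2 lie within the scatter of each other, while compound 1 gives a lower number, a gap beyond the scatter. Compound 4 `N#C[Se]c1ccc(NC(=O)OCc2ccccc2)cc1` differs from compound 3 by hydrogen in place of nitro on an aromatic carbon. Going by the values given here, the only measured step, a 3.0-fold higher number from compound 1 to compound 2 (0.48 log units; beyond the scatter), concerns the chain on the oxygen side of the shared core and does not touch the nitro group, so no measured step bears directly on this change. The expectation for compound 4 in this assay is therefore a step of about a 1.1-fold lower number from compound 3 to compound 4 (0.05 log units; within the scatter), a number near that of compound 3 with no move beyond the scatter. Compound 4 is estimated at 20000 nM, with a range from 8000 nM to 50000 nM.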

Compound 4, concentration for 50% growth inhibition: 13300 nM
Compound 4: the middle estimate sits 1.5-fold (0.18 log units) above what was measured, within the range that was stated.
By their numbers in this assay, from the lowest: compounds 1, 4, 3 and 2 (each within the scatter of the next, the first and the last beyond it).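

In this assay, hydrogen in place of nitro on the aromatic carbon gives a 1.7-fold lower number from compound 3 to compound 4 (0.23 log units; within the scatter), so this first look at that place shows a change no larger than the scatter. Phenyl in place of vinyl gives a 1.8-fold lower number from compound 2 to compound 4 (0.27 log units; within the scatter) and phenyl in place of isopropyl gives a 1.6-fold higher number from compound 1 to compound 4 (0.22 log units; within the scatter), so the phenyl compound lies within the scatter of two compounds that lie beyond the scatter of each other. Nothing available explains these results. From the compounds shown here alone, whether an amine or a carboxylic acid on that aromatic carbon would give a step beyond the scatter remains open, as does the effect of a longer chain on the oxygen.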